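The compounds below may be only part of what the source reports. "The series", "measured", "known", "first", "only" and "open" are said of these compounds alone.

Among the compounds with values here, in a physicochemical assay for solubility, in simulated intestinal fluid, measured as thermodynamic solubility, at pH 6.8 (a lower number here means a less soluble compound, a higher number a more soluble compound), compound 2 `CC(=O)NC1CCN(c2nc3c(c(Nc4ccc(C(F)(F)F)cc4)n2)CCN(c2ncccc2C(F)(F)F)CC3)C1` gives 19 ug/mL as the only exact number so far. Compound 1 `NC1CCN(c2nc3c(c(Nc4ccc(C(F)(F)F)cc4)n2)CCN(c2ncccc2C(F)(F)F)CC3)C1` reads > 215 ug/mL and that is a limit of the assay, not a number. Compound 3 `FC(F)(F)c1ccc(Nc2nc(NC3CCCNC3)nc3c2CCN(c2ncccc2C(F)(F)F)CC3)cc1` has (piperidin-3-yl)amino in place of 3-acetamidopyrrolidin-1-yl on an aromatic carbon, a swap counted as (piperidin-3-yl)amino in place of 3-acetamidopyrrolidin-1-yl on an aromatic carbon in full. Within the data shown here, the one measured step that bears on this is an at least 11-fold lower number from compound 1 to compound 2 (1.05 log units; beyond the scatter) with acetyl in place of hydrogen on an amine nitrogen, a large step. Compound 3 carries no acetyl, so reversing an at least 11-fold lower number from compound 1 to compound 2 (1.05 log units; beyond the scatter) points to a higher number in this assay for this new compound. Among the measured compounds shown here, no measured step covers the change of ring, which leaves the expectation loose. The expected step is a 6.3-fold higher number from compound 2 to compound 3 (0.80 log units; beyond the scatter) in the upward direction. For compound 3 the estimate is 120 ug/mL with an expected range from 40 ug/mL to 300 ug/mL overall.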

Compound 3, solubility: 203 ug/mL
Estimate against measurement, compound 3: 1.7-fold (0.23 log units) below; the range from low to high includes it.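

In this assay, putting (piperidin-3-yl)amino in place of 3-acetamidopyrrolidin-1-yl on this aromatic carbon gives an 11-fold higher number from compound 2 to compound 3 (1.03 log units; beyond the scatter). So a second group without the acetyl, this one with a six-membered non-aromatic ring, also reads far from the acetylated compound. The other comparison, an at least 1.0-fold lower number from compound 1 to compound 3 (0.02 log units; that floor lies within the scatter), gives only a floor, and the order of that pair cannot be read because one of its values is a limit of the assay: the limit of > 215 ug/mL in this assay, at which 1 of the 3 values shown sits.

Going by these compounds, this single swap changes the ring size, the point of attachment and the acetyl together, so the share of each in the step stays open. On these data alone, how a carboxylic acid or a morpholine ring would read at this position also remains open.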